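Shortening the amine chain further: compound 3

This account rests on a few compounds, and the source may have more. Where it says the series, first, only, none or still open, it means among the compounds named here.

- compound 1 `NCCCCCOc1ccc([C@H]2CC[C@]3(CC2)OOC2(O3)C3CC4CC(C3)CC2C4)cc1`: < 7 mL.min-1.g-1
- compound 2 `NCCCOc1ccc([C@H]2CC[C@]3(CC2)OOC2(O3)C3CC4CC(C3)CC2C4)cc1`: < 7 mL.min-1.g-1

In an ADME assay on microsomes from liver (Homo sapiens) for metabolic stability, read by LC-MS, tested at 1 uM (on this read-out higher numbers stand for fast clearance and lower numbers for slow clearance), compound 2 gives < 7 mL.min-1.g-1, which is a limit and not a number. Among the measured compounds shown here, the series so far rests on (the limit of < 7 mL.min-1.g-1 in this assay, at which 2 of the 2 values shown sit). Compound 3 `NCCOc1ccc([C@H]2CC[C@]3(CC2)OOC2(O3)C3CC4CC(C3)CC2C4)cc1` carries amino in place of aminomethyl on a saturated chain carbon, two bonds along the chain from an oxygen on an aromatic ring, the change from 3-aminopropoxy to 2-aminoethoxy. For the measured compounds named here, the one measured step of this kind is a step that the two limits leave unreadable from compound 1 to compound 2. It offers no size to carry over, so no step beyond the scatter is expected. The estimated step is a step that the limit leaves unreadable from compound 2 to compound 3. Compound 3 is expected at 5 mL.min-1.g-1, with an estimated range of 2 mL.min-1.g-1 to 10 mL.min-1.g-1.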

Compound 3, intrinsic clearance in microsomes: < 7 mL.min-1.g-1
Compound 3 was reported as a limit; the forecaster's own chance of this, stated with the estimate: 85%; the middle value lies beyond the limit too.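

In this assay, among the compounds shown here, compound 3 gives < 7 mL.min-1.g-1, a limit like those of compound 1 and compound 2, so no step among the three can be read. As far as these compounds go, whether amine chain length changes clearance at all stays open.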